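The compounds below may be only part of what the source reports. "The series", "measured", "known", "first", "only" and "open" are said of these compounds alone.

Measured compounds:
- compound 1, `COc1ccc(/C=C/C(=O)c2cc(-c3ccc(OC)c(OC)c3)n3nc(-c4ccccc4)cc3n2)cc1`: 14900 nM
- compound 2, `COc1ccc(-c2cc(/C=C/C(=O)c3ccc(OC)c(OC)c3)nc3cc(-c4ccccc4)nn23)cc1`: 16400 nM
- compound 3, `COc1ccc(/C=C/C(=O)c2cc(-c3cc(OC)c(OC)c(OC)c3)n3nc(-c4ccccc4)cc3n2)cc1`: 16900 nM

All three were tested in a functional assay on DU-145 cells (Homo sapiens) for antiproliferative activity, read by MTT assay, with a stated time of 24 h; a lower number here means a stronger inhibitor, a higher number a weaker inhibitor. Compound 1 gives the lowest of the three numbers, but the gaps to its neighbours are small: the step of a 1.1-fold higher number from compound 1 to compound 3 (0.05 log units; within the scatter) is within the scatter, and compound 2, which differs from compound 1 in more than one place, gives a value that likewise sits within the scatter of compound 1. The three compounds are therefore indistinguishable on these numbers.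

Compound 4, `COc1ccc(-c2cc(/C=C/C(=O)c3ccc(Cl)cc3)nc3cc(-c4ccccc4)nn23)cc1OC`, has not yet been measured. It differs from compound 1 in one place: 2-((4-chlorophenyl)carbonyl)ethenyl in place of (2-(4-methoxyphenyl)ethenyl)carbonyl on an aromatic carbon. Among the measured compounds shown here, no measured step isolates this change. For the measured compounds named here, the only step on record, from compound 1 to compound 3, concerns a methoxy group elsewhere and is within the scatter; compound 2, which carries the reversed enone arm together with a different set of methoxy groups, shows no departure from compound 1 beyond the scatter. Going by the values given here, with every number so far lying in a narrow band, the expected step of a 1.0-fold higher number from compound 1 to compound 4 (0.00 log units; within the scatter) is small and in no clear direction. Compound 4 is therefore estimated to give 15000 nM in this assay, with a range from 5000 nM to 45000 nM.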

Compound 4, half-maximal inhibitory concentration: 21300 nM
For compound 4 the middle estimate is 1.4-fold (0.15 log units) below the measured one; measured number inside the range.
By their numbers in this assay, from the lowest: compounds 1, 2, 3 and 4 (each within the scatter of the next).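

In this assay, among the compounds shown here, putting 2-((4-chlorophenyl)carbonyl)ethenyl in place of (2-(4-methoxyphenyl)ethenyl)carbonyl gives a 1.4-fold higher number from compound 1 to compound 4 (0.16 log units; within the scatter) and provides the first comparison that isolates a change at this aromatic carbon next to the ring nitrogen. The whole arm can thus be exchanged here, with the carbonyl moved to the other end of the ethenyl link and chlorine replacing methoxy on the terminal ring, without a departure beyond the scatter. Because these changes arrive together in one step, the comparison cannot assign any share of the difference to either one, and no measurement is available here that would explain why the two arms read alike.

On these data alone, what remains open is whether the direction of the carbonyl and the chlorine would each leave the number within the scatter if changed alone. As far as these compounds go, it is also open whether a more different arm at this position, such as one ending in a carboxylic acid or a morpholine, or a saturated ethyl link in place of the ethenyl link, would give a step beyond the scatter.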